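A Methyl Removed from the Shared Core of Compound 3

This account rests on a few compounds, and the source may have more. Where it says the series, first, only, none or still open, it means among the compounds named here.

Compound 1 `N/C(=N\NC(=S)N1CCCC1)c1ccc(F)cn1` — 78.7%
Compound 2 `N/C(=N\NC(=S)N1CCCCC1)c1ccccn1` — 68.1%
Compound 3 `Cc1cccc(/C(N)=N/NC(=S)N2CCCC2)n1` — 67.6%

All three compounds were tested in a functional assay on A-431 cells (Homo sapiens) for cytotoxicity, read by MTT assay, with a stated time of 72 h, tested at 10 uM; on this read-out lower numbers stand for less inhibition of growth and higher numbers for more inhibition of growth at the one concentration tested. Compound 3 gives 67.6%, the lowest number of the three, but the gap to compound 2 is within the scatter of repeated measurements, and only the gap to compound 1 is beyond it. Compound 4 `N/C(=N\NC(=S)N1CCCC1)c1ccccn1` differs from compound 3 in a single place: hydrogen in place of methyl on an aromatic carbon. Within the data shown here, no pair of measured compounds differs in one place only, so no measured step is available for this kind of change. The expectation for the step is small, and most likely not beyond the scatter, because compound 2 also carries no methyl on its six-membered aromatic ring and gives 68.1% in this assay . Compound 4 is therefore expected to give about 71%, within a range of 60% to 82%. That estimate means an expected step of a number 3.4 percentage points higher from compound 3 to compound 4 (within the scatter), a change that would stay inside the usual scatter.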

Compound 4, percent growth inhibition at one concentration: 77.2%
Compound 4: middle estimate off by 6.2 percentage points, on the low side, within the range that was stated.
By their numbers in this assay, from the lowest: compounds 3, 2, 4 and 1 (each within the scatter of the next, the first and the last beyond it).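

In this assay, hydrogen in place of methyl on the aromatic carbon next to the ring nitrogen gives a number 9.6 percentage points higher from compound 3 to compound 4 (within the scatter), so the compounds shown give no firm sign that the methyl matters at this position. The two other new steps read the same way: pyrrolidin-1-yl in place of piperidin-1-yl on the thiocarbonyl carbon gives a number 9.1 percentage points higher from compound 2 to compound 4 (within the scatter), and swapping the fluoro group for hydrogen gives a number 1.5 percentage points lower from compound 1 to compound 4 (within the scatter). Nothing measured here speaks to what lies behind these numbers.

At this position the compounds shown compare only methyl and hydrogen, so it stays open whether an amine, a methoxy group or a carboxylic acid there would give a step beyond the scatter. Each compound is also seen at a single concentration, which leaves open how the compounds compare at other concentrations.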